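The source may report more compounds than this note shows. Statements on the series, on what has been measured and on what is new or still open speak of the compounds shown alone.

Measured so far:
- compound 1 `CNC(=O)c1cc(Oc2ccc3nc(Nc4ccccc4)ncc3c2)ccn1`: in an ADME assay on Caco-2 cells (Homo sapiens) for permeability, in the apical to basolateral direction (on this read-out higher numbers stand for higher permeability and lower numbers for lower permeability), compound 1 gives < 1 10^-6 cm/s, a limit of the assay.
- compound 2 `CNC(=O)c1cc(Oc2ccc3nc(Nc4cccc(C(C)(C)C)c4)ccc3c2)ccn1`: compound 2 gives < 1 10^-6 cm/s, also a limit.
- compound 3 `CNC(=O)c1cc(Oc2ccc3nc(Nc4cccc(Cl)c4)ncc3c2)ccn1`: compound 3 gives < 1 10^-6 cm/s, again a limit.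

Compound 3 therefore stands only at a limit, as do the two other values shown; (the limit of < 1 10^-6 cm/s in this assay, at which 3 of the 3 values shown sit). Within the data shown here, the one single-point step, a step that the two limits leave unreadable from compound 1 to compound 3, cannot be read from two limits.

Compound 4 `CNC(=O)c1cc(Oc2ccc3nc(Nc4cccc(C(C)C)c4)ncc3c2)ccn1` differs from compound 3 by isopropyl in place of chloro on an aromatic carbon. No measured step covers isopropyl, and the chloro step gives no readable size, so nothing shown supports movement beyond the scatter in this assay.

Compound 4 is expected to sit at the limit as well, estimated at 0.5 10^-6 cm/s within 0.2 10^-6 cm/s to 2 10^-6 cm/s, a step that the limit leaves unreadable from compound 3 to compound 4 expected to be unreadable.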

Compound 4, apparent permeability: < 1 10^-6 cm/s
Compound 4: only a limit was reported; the forecaster's own chance of this, stated with the estimate: 80%; the middle value lies beyond the limit too.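

Among these compounds, compound 4 sits at a limit, as do compound 1 and compound 3, so no step to compound 4 can be read: the limit of < 1 10^-6 cm/s in this assay, at which 4 of the 4 values shown sit.

In this assay the compounds shown leave open how far each lies beyond that limit, and whether any change gives a readable value.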